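Swapping Methoxy for Dimethylcarbamoyl on a Fatty Acid Receptor Agonist

The source may report more compounds than this note shows. Statements on the series, on what has been measured and on what is new or still open speak of the compounds shown alone.

Compound 1 `O=C(O)CC(c1ccc(OCC2COc3ccc(Cl)cc3O2)cc1)c1cnco1` gives 1030 nM in a functional assay on HEK293 cells for agonist activity at Free fatty acid receptor 1 (Homo sapiens), read by fluorescence and calcium flux, with a stated time of 10 min; on this read-out higher numbers stand for an effect only at larger amounts of compound and lower numbers for an effect already at smaller amounts.
Compound 2 `O=C(O)CC(c1ccc(F)cc1)c1ccc(OCC2COc3ccc(Cl)cc3O2)cc1` gives 4310 nM in this assay.
Compound 3 `CC#C[C@@H](CC(=O)O)c1ccc(OC[C@H]2COc3ccc(OC)cc3O2)cc1` gives 130 nM in this assay.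

Compound 3 stands lowest of the three, with compound 1 nearest and compound 2 furthest away. Within the data shown here, the only single-site step measured so far is a 4.2-fold higher number from compound 1 to compound 2 (0.62 log units; beyond the scatter), and it concerns a different part of the molecule. Compound 4 `CC#C[C@@H](CC(=O)O)c1ccc(OC[C@H]2COc3ccc(C(=O)N(C)C)cc3O2)cc1` differs from compound 3 by dimethylcarbamoyl in place of methoxy on an aromatic carbon. Among the measured compounds shown here, no measured pair speaks to that position, so nothing can be carried over, and a change of no more than the usual scatter is expected: the estimated step is a 1.2-fold higher number from compound 3 to compound 4 (0.06 log units; within the scatter). Compound 4 is therefore expected to give about 150 nM, within a range from 40 nM to 600 nM.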

Compound 4, half-maximal effective concentration: > 30000 nM
Compound 4 gave a limit, no number; the forecaster's own chance of this, stated with the estimate: 5%; middle value at least 200-fold (2.30 log units) from the limit.
By their numbers in this assay, from the lowest: compound 3; then compound 1; then compound 2. At a limit, above all of these: compound 4.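

Among these compounds, changing this one group on the aromatic ring of the shared core has a large effect, which no earlier compound could show: dimethylcarbamoyl in place of methoxy gives an at least 230-fold higher number from compound 3 to compound 4 (2.36 log units; beyond the scatter). The group at this place therefore strongly affects the amount of compound needed in this assay. Compound 4 gave only a limit, > 30000 nM, so the full size of the step is unknown: the limit of > 30000 nM in this assay, at which 1 of the 4 values shown sits.

On these data alone, whether an ethoxy group or a primary carboxamide at this place would keep the effect remains open. The data also do not separate the size of the entering group from its carbonyl or its nitrogen.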